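Ethynyl replaces 3-fluorophenyl on the alkoxyimino side chain

This account rests on a few compounds, and the source may have more. Where it says the series, first, only, none or still open, it means among the compounds named here.

Measured compounds:
compound 1 `O=C(O)CCCO/N=c1/ccn([C@@H]2O[C@H](COP(=O)(O)OP(=O)(O)OP(=O)(O)O)[C@@H](O)[C@H]2O)c(=O)[nH]1` gives 697 nM
compound 2 `O=c1[nH]/c(=N\OCCCc2cccc(F)c2)ccn1[C@@H]1O[C@H](COP(=O)(O)OP(=O)(O)OP(=O)(O)O)[C@@H](O)[C@H]1O` gives 539 nM
compound 3 `O=c1[nH]/c(=N\OCCCc2ccc(Br)cc2)ccn1[C@@H]1O[C@H](COP(=O)(O)OP(=O)(O)OP(=O)(O)O)[C@@H](O)[C@H]1O` gives 225 nM

In a functional assay on 1321-N1 cells for agonist activity at P2Y purinoceptor 6 (Homo sapiens), read by scintillation counting and inositol phosphate accumulation (a lower number here means that less compound is needed, a higher number that more compound is needed for the effect), compound 2 holds the second highest of the three numbers: its nearest neighbour is compound 1, and the step of a 1.3-fold lower number from compound 1 to compound 2 (0.11 log units; within the scatter) lies within the scatter, while the step of a 2.4-fold lower number from compound 2 to compound 3 (0.38 log units; beyond the scatter) lies beyond it. The unmeasured compound 4 `C#CCCCO/N=c1/ccn([C@@H]2O[C@H](COP(=O)(O)OP(=O)(O)OP(=O)(O)O)[C@@H](O)[C@H]2O)c(=O)[nH]1` differs from compound 2 by ethynyl in place of 3-fluorophenyl on a saturated chain carbon, three bonds along the chain from an oxygen.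

Within the data shown here, two measured steps touch this position on the chain. The step of a 1.3-fold lower number from compound 1 to compound 2 (0.11 log units; within the scatter) shows that trading carboxy for 3-fluorophenyl there hardly moved the number, and the step of a 2.4-fold lower number from compound 2 to compound 3 (0.38 log units; beyond the scatter) shows that a second aryl group gave only a modest lowering. Among the measured compounds shown here, nothing measured carries ethynyl, so the effect of so small a group has no direct precedent. On the evidence of compound 1 with 697 nM and compound 2 with 539 nM, the position tolerates groups of very different kind with little change, and compound 4 is therefore expected to show a step of a 1.2-fold higher number from compound 2 to compound 4 (0.08 log units; within the scatter) that stays within the scatter or drifts slightly toward a higher number. Compound 4 is estimated at 650 nM, with a range from 250 nM to 1700 nM.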

Compound 4, half-maximal effective concentration: 3000 nM
For compound 4 the middle estimate is 4.6-fold (0.66 log units) below the measured one, outside the stated range (above it).
By their numbers in this assay, from the lowest: compound 3; then compounds 2 and 1 (each within the scatter of the next); then compound 4.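

Among these compounds, the position proves less forgiving than the earlier compounds suggested: in this assay, ethynyl in place of an aryl group gives a 5.6-fold higher number from compound 2 to compound 4 (0.75 log units; beyond the scatter) and a 13-fold higher number from compound 3 to compound 4 (1.12 log units; beyond the scatter). Ethynyl also separates from carboxy, with a 4.3-fold higher number from compound 1 to compound 4 (0.63 log units; beyond the scatter), so a group without a ring does not by that fact alone match compound 1, and ethynyl stands apart from all three groups seen earlier. Nothing available bears on the reason for this result.

The compounds shown leave open whether the higher number goes with the loss of the aromatic ring or with the triple bond itself, which a vinyl or ethyl group in place of ethynyl would help to separate. Also open, from the compounds shown here alone, is how an amine or a nitrile would behave on the same chain.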